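The source may hold more compounds than are shown below. What is called first, only, known or untested is meant among the compounds shown, and "the series" means these compounds.

Working notes on the series. Compound 1 `CC(Oc1cccc(Cl)c1)c1nc(N)nc(N2CCN(C)CC2)n1` gives 8360 nM in an assay on HEK293 cells for displacement of a labelled ligand from 5-hydroxytryptamine receptor 7 (Homo sapiens), read by radioligand binding, with a stated time of 1 h; on this read-out higher numbers stand for weaker inhibition and lower numbers for stronger inhibition. Among the measured compounds shown here, compound 2 `CN1CCN(c2nc(N)nc(CSc3ccccc3Cl)n2)CC1` gives 614 nM in this assay, the lowest of the two numbers so far; compound 1 stands beyond the scatter above it. Compound 3 `CC(Sc1ccccc1Cl)c1nc(N)nc(N2CCN(C)CC2)n1` is not yet measured. It differs from compound 2 by methyl in place of hydrogen on a saturated chain carbon bound to an aromatic carbon and a sulfur. For the measured compounds named here, no single-point step of this kind is available among the measured compounds, and compound 1 differs from compound 3 in more than one place, so no direction can be read from it. The step from compound 2 to compound 3 is expected to be small, a 1.5-fold higher number from compound 2 to compound 3 (0.17 log units; within the scatter), perhaps a slight weakening. Compound 3 is estimated at 900 nM, with a range of 300 nM to 3000 nM.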

Compound 3, inhibition constant: 4570 nM
Estimate against measurement, compound 3: 5.1-fold (0.71 log units) below; the measured number lies above the stated range.
By their numbers in this assay, from the lowest: compound 2; then compounds 3 and 1 (each within the scatter of the next).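

In this assay, methyl in place of hydrogen on a saturated chain carbon bound to an aromatic carbon and a sulfur is not a neutral change: it gives a 7.4-fold higher number from compound 2 to compound 3 (0.87 log units; beyond the scatter), so one added carbon here is enough to weaken the result. With that methyl present, (2-chlorophenyl)sulfanyl in place of 3-chlorophenoxy gives a 1.8-fold lower number from compound 1 to compound 3 (0.26 log units; within the scatter), which leaves the two compounds unseparated. Nothing on hand accounts for the methyl step. The compounds shown leave open whether an ethyl group or a hydroxyl on this carbon would behave as methyl does.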